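Purine riboside analogues in equilibrative nucleoside transporter binding

This account rests on a few compounds, and the source may have more. Where it says the series, first, only, none or still open, it means among the compounds named here.

Compound 1: `O=[N+]([O-])c1ccc2c(c1)CN(c1ncnc3c1nc1n3[C@@H]3O[C@H](CO1)[C@@H](O)[C@H]3O)CC2` — 331 nM
Compound 2: `CCCCCNc1ncnc2c1ncn2[C@@H]1O[C@H](CO)[C@@H](O)[C@H]1O` — 13500 nM

Of the compounds shown here, two have been measured in an assay on isolated protein for binding affinity to Equilibrative nucleoside transporter 1 (Homo sapiens); on this read-out higher numbers stand for weaker inhibition and lower numbers for stronger inhibition. Compound 1 `O=[N+]([O-])c1ccc2c(c1)CN(c1ncnc3c1nc1n3[C@@H]3O[C@H](CO1)[C@@H](O)[C@H]3O)CC2` gives 331 nM in this assay. Compound 2 `CCCCCNc1ncnc2c1ncn2[C@@H]1O[C@H](CO)[C@@H](O)[C@H]1O` gives 13500 nM in this assay, the highest of the two numbers, and the gap between compound 1 and compound 2 lies well beyond the scatter of this measurement. The two structures differ in several places at once, so nothing about any single change can be read from them.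

Compound 3 `OC[C@H]1O[C@@H](n2cnc3c(SC4CCCCC4)ncnc32)[C@H](O)[C@@H]1O` is not yet measured. It differs from compound 2 in one place: cyclohexylsulfanyl in place of pentylamino on an aromatic carbon The shared core of compound 2 and compound 3 is otherwise unchanged.

For the measured compounds named here, no measured pair shows what this exchange does to the number, so the direction of the step has to be guessed. The expectation is a modest move toward stronger inhibition, and the step from compound 2 to compound 3 is estimated as a 3.4-fold lower number from compound 2 to compound 3 (0.53 log units; beyond the scatter) in this assay. For compound 3 the estimate in this assay is 4000 nM, with a plausible range from 600 nM to 25000 nM.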

Compound 3, half-maximal inhibitory concentration: 6310 nM
Compound 3: the middle estimate sits 1.6-fold (0.20 log units) below what was measured; low and high end bracket the measured number.
By their numbers in this assay, from the lowest: compound 1; then compound 3; then compound 2.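

For the compounds shown here, at this aromatic carbon of the shared core, cyclohexylsulfanyl in place of pentylamino gives a 2.1-fold lower number from compound 2 to compound 3 (0.33 log units; beyond the scatter) in this assay and is the only single-place step so far. The position therefore accepts the loss of the hydrogen-bond donor of pentylamino and the entry of a six-membered non-aromatic carbon ring without any move toward weaker inhibition, and the step is modest rather than large. The sulfur, the ring and the donor all change in this one exchange, and no measurement at hand bears on what lies behind the step.

On these data alone, whether the lower number belongs to the sulfur or to the ring remains open: cyclohexylamino or pentylsulfanyl at this same carbon, each changing only one of the two features, would separate them. Also open, as far as these compounds go, is whether a different ring on the sulfur moves the number further, as cyclopentylsulfanyl or phenylsulfanyl at this carbon would show.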